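Changing the Long Chain of Compound 2

This account rests on a few compounds, and the source may have more. Where it says the series, first, only, none or still open, it means among the compounds named here.

Among the compounds with values here, in a functional assay on WM164 cells (Homo sapiens) for antiproliferative activity, read by sulforhodamine B assay, with a stated time of 48 h (on this read-out lower numbers stand for stronger inhibition and higher numbers for weaker inhibition), compound 1 (`CCCCCCCCCCCCCCCCNC(=O)[C@@H]1CSC(c2ccc(OC)c(OC)c2)N1`) gives 500 nM and compound 2 (`CCCCCCCCCCCCCCCCNC(=O)[C@@H]1CSC(c2ccc(NC(C)=O)cc2)N1`) gives 600 nM in the same test, so compound 2 stands level with its only neighbour. Compound 3 (`CCCCCCCCC/C=C\CCCCCCCNC(=O)[C@@H]1CSC(c2ccc(NC(C)=O)cc2)N1`) differs from compound 2 in the chain alone: a group of 11 heavy atoms (11 carbon; no ring) in place of a group of 9 heavy atoms (9 carbon; no ring), on a saturated chain carbon, seven bonds along the chain from an amide-type nitrogen is the whole change. Within the data shown here, the one measured step is a 1.2-fold higher number from compound 1 to compound 2 (0.08 log units; within the scatter) and it lies within the scatter at another place on the molecule, so no measurement tests the chain. In this assay the expected step is therefore no change at the digits printed from compound 2 to compound 3 (within the scatter) with nothing beyond the scatter foreseen. For compound 3 the estimated value is 600 nM with an expected range from 250 nM to 1500 nM in this test.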

Compound 3, half-maximal inhibitory concentration: 1000 nM
Compound 3: middle estimate off by 1.7-fold (0.22 log units), on the low side, and the stated range covers the measured number.
By their numbers in this assay, from the lowest: compounds 1, 2 and 3 (each within the scatter of the next).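

Within the data shown here, the chain is now tested for the first time: in this assay, replacing nonyl with a longer group holding one double bond gives a 1.7-fold higher number from compound 2 to compound 3 (0.22 log units; within the scatter). At this position, then, this change in length and saturation together moves the number no further than the usual scatter. Nothing available gives a reason for this result.

Because length and the double bond changed together, their separate contributions cannot be told apart. Going by these compounds, whether a shorter chain such as butyl, or an amine or carboxylic acid at the chain end, would change the number remains open.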